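Compound 4: phenyl in place of 3,4-dihydroxyphenyl

The source may hold more compounds than are shown below. What is called first, only, known or untested is meant among the compounds shown, and "the series" means these compounds.

In a functional assay (Mus musculus) for inhibition, with a stated time of 5 days (on this read-out lower numbers stand for stronger inhibition and higher numbers for weaker inhibition), compound 1 `O=Cc1cn(-c2ccc(O)cc2)nc1-c1ccc(O)c(O)c1` gives 12000 nM and compound 3 `CCOC(=O)/C=C/c1cn(-c2ccc(O)cc2)nc1-c1ccc(O)c(O)c1` gives 6200 nM. Compound 2 `O=C(O)/C=C/c1cn(-c2ccc(O)cc2)nc1-c1ccc(O)c(O)c1` gives only a limit of the assay, > 100000 nM, and no true number. Compound 4 `O=C(O)/C=C/c1cn(-c2ccc(O)cc2)nc1-c1ccccc1` differs from it by having phenyl in place of 3,4-dihydroxyphenyl on an aromatic carbon. Two measured steps involve compound 2: one at least modest, an at least 8.3-fold higher number from compound 1 to compound 2 (0.92 log units; beyond the scatter), and one large, an at least 16-fold lower number from compound 2 to compound 3 (1.20 log units; beyond the scatter). Both change only the 2-carboxyethenyl group, which compound 4 keeps, and neither touches 3,4-dihydroxyphenyl. With no measured guide to a shift, the expected change is none beyond the scatter, a step that the limit leaves unreadable from compound 2 to compound 4, and a further limit is likely. For compound 4 the estimated value is 120000 nM, within a range of 40000 nM to 300000 nM.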

Compound 4, half-maximal inhibitory concentration: > 100000 nM
Compound 4 ended at the assay's limit; the forecaster's own chance of this, stated with the estimate: 75%; the middle value is on the limit's open side.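

Going by these compounds alone, compound 2 and compound 4 both stop at a limit of this assay rather than a true number, so no step between them can be read. On these data alone, whether phenyl in place of 3,4-dihydroxyphenyl changes inhibition at all remains open.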